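Swapping the amide substituent toward a cyclobutyl

The source may hold more compounds than are shown below. What is called first, only, known or untested is meant among the compounds shown, and "the series" means these compounds.

Measured so far in an assay on HEK293 cells for negative allosteric modulation of metabotropic glutamate receptor 5 (Homo sapiens), read by FLIPR; a higher number here means a weaker inhibitor, a lower number a stronger inhibitor:
Compound 1 `CC1CCC(C(=O)N2CC(c3nc(-c4cccc(Cl)c4)no3)C2)CC1`: > 10000 nM, a limit of the assay rather than a number.
Compound 2 `O=C(C1CCCO1)N1CC(c2nc(-c3cccc(Cl)c3)no2)C1`: 890 nM.
Compound 3 `O=C(c1ccc(F)cc1)N1CC(c2nc(-c3cccc(Cl)c3)no2)C1`: 4000 nM.

Compound 3 holds the highest of the two numbers in this assay. Its distance from the nearest number is given by a 4.5-fold higher number from compound 2 to compound 3 (0.65 log units; beyond the scatter), and the move from the limit where compound 1 sits is an at least 2.5-fold lower number from compound 1 to compound 3 (0.39 log units; beyond the scatter); that limit is the limit of > 10000 nM in this assay, at which 1 of the 3 values shown sits.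

Compound 4 `O=C(C1CCC1)N1CC(c2nc(-c3cccc(Cl)c3)no2)C1` differs from compound 3 by cyclobutyl in place of 4-fluorophenyl on a carbonyl carbon. Among the compounds with values here, two measured steps bear on this change, both exchanging a non-aromatic ring for the 4-fluorophenyl: the large rise from the oxolan-2-yl amide, a 4.5-fold higher number from compound 2 to compound 3 (0.65 log units; beyond the scatter), and the drop from the 4-methylcyclohexyl amide, an at least 2.5-fold lower number from compound 1 to compound 3 (0.39 log units; beyond the scatter). Read backwards, a non-aromatic ring in place of the 4-fluorophenyl has gone either way. Cyclobutyl is a carbon-only ring like 4-methylcyclohexyl yet far smaller, closer in size to oxolan-2-yl. The balance of these two steps points to a modest lowering, with wide uncertainty. Compound 4 is therefore expected to give 2000 nM, within 500 nM to 8000 nM. The expected step is a 2.0-fold lower number from compound 3 to compound 4 (0.30 log units; within the scatter).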

Compound 4, half-maximal inhibitory concentration: 1500 nM
Compound 4: middle estimate off by 1.3-fold (0.12 log units), on the high side; measured number inside the range.
By their numbers in this assay, from the lowest: compounds 2 and 4 (each within the scatter of the next); then compound 3. At a limit, above all of these: compound 1.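

In this assay, the cyclobutyl amide gives a 2.7-fold lower number from compound 3 to compound 4 (0.43 log units; beyond the scatter), so on this carbonyl carbon a small carbon-only ring improves on the 4-fluorophenyl, while against the oxolan-2-yl amide the change gives a 1.7-fold higher number from compound 2 to compound 4 (0.23 log units; within the scatter), which does not separate the two rings and shows that the oxygen of oxolan-2-yl is not needed to reach a number of this size. Carbon-only non-aromatic rings at this position do not all behave alike, as the 4-methylcyclohexyl and cyclobutyl amides are set apart by an at least 6.6-fold lower number from compound 1 to compound 4 (0.82 log units; beyond the scatter). Compound 1 holds a limit of the assay and not a number: the limit of > 10000 nM in this assay, at which 1 of the 4 values shown sits.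

On these data alone, what remains open is whether other rings on the carbonyl carbon, such as cyclopropyl, cyclopentyl or a tetrahydropyran, or an open chain such as isobutyl, would match or go lower than compounds 2 and 4. The shared core stays fixed throughout, so nothing here shows whether the same order of amides would hold if the core changed.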